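The compounds below may be only part of what the source reports. "The series", "measured", "known", "first", "only" and "open" are said of these compounds alone.

In an ADME assay on HEK-293T cells (Homo sapiens) for cytotoxicity, read by luminescence and CellTiter-Glo, with a stated time of 24 h (on this read-out lower numbers stand for higher toxicity in this test and higher numbers for lower toxicity in this test), compound 1 `CCCNC(=O)C1CCN(C(=O)c2cc3sc(Br)cc3n2Cc2ccc(OC)cc2)CC1` gives > 100000 nM; > 100000 nM (2 entries), a limit of the assay rather than a number. In this assay compound 2 `CCCNC(=O)C1CCN(C(=O)c2cc3sc(-c4ccccc4)cc3n2Cc2ccc(OC)cc2)CC1` gives > 100000 nM, likewise only a limit. For the measured compounds named here, compound 2 thus stands at the limit of > 100000 nM in this assay, at which 1 of the 2 values shown sits; no measured step between compounds is available. Compound 3 `CCCNC(=O)C1CCN(C(=O)c2cc3sccc3n2Cc2ccc(OC)cc2)CC1` differs from compound 2 by hydrogen in place of phenyl on an aromatic carbon. Both measured compounds sit at the limit, so no step beyond the scatter is expected: a step that the limit leaves unreadable from compound 2 to compound 3. Compound 3 is expected to give 150000 nM in this assay, within 50000 nM to 400000 nM, most likely again reported as a limit.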

Compound 3, half-maximal cytotoxic concentration: 18800 nM
Compound 3: the middle estimate sits 8.0-fold (0.90 log units) above what was measured; the whole stated range lies above it.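

In this assay, the aromatic carbon next to the ring sulfur now proves sensitive to what it carries: an at least 5.3-fold lower number from compound 2 to compound 3 (0.72 log units; beyond the scatter). Removing the phenyl thus gives higher toxicity in this test, and compound 3 is the only compound shown with a number rather than a limit. Compound 1, with bromine on that carbon, gives > 100000 nM; > 100000 nM (2 entries), which is also a limit.

The full size of the step stays unread, as compound 2 gives only a limit. On these data alone, whether a methyl group or an amine on this carbon would give a number or a limit remains open.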